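Fluorophenyl for Pyridinyl on a Chalcone Boronic Acid Core

The source may hold more compounds than are shown below. What is called first, only, known or untested is meant among the compounds shown, and "the series" means these compounds.

Of the compounds shown here, two sharing a cyclic boronic ester core have been measured. Compound 1 `O=C(/C=C/c1ccc2c(c1)B(O)OC2)c1cccnc1` gives 76200 nM in a toxicity assay on WI-38 cells (Homo sapiens) for cytotoxicity, read by MTT assay, with a stated time of 48 h (a lower number here means a stronger inhibitor, a higher number a weaker inhibitor), which is the higher of the two numbers recorded. Compound 2 `CCOC(=O)c1ccc(C(=O)/C=C/c2ccc3c(c2)B(O)OC3)cc1` gives 47200 nM in this assay; its number lies within the usual scatter of that of compound 1, so no order can be drawn between them.

The unmeasured compound 3 `O=C(/C=C/c1ccc2c(c1)B(O)OC2)c1ccccc1F` differs from compound 1 in one place: 2-fluorophenyl in place of pyridin-3-yl on a carbonyl carbon. For the measured compounds named here, nothing measured so far speaks to this change, as no pair of measured compounds differs by it. Given that both measured compounds sit close together, the step from compound 1 to compound 3 is expected to be small, a 1.3-fold lower number from compound 1 to compound 3 (0.10 log units; within the scatter), with no direction beyond the scatter. Compound 3 is therefore estimated at 60000 nM, with a range from 25000 nM to 150000 nM.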

Compound 3, half-maximal inhibitory concentration: 23600 nM
The estimate for compound 3 lay 2.5-fold (0.41 log units) above the measured number; the measured number lies below the stated range.
By their numbers in this assay, from the lowest: compounds 3, 2 and 1 (each within the scatter of the next, the first and the last beyond it).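

In this assay, for the compounds shown here, 2-fluorophenyl in place of pyridin-3-yl on a carbonyl carbon gives a 3.2-fold lower number from compound 1 to compound 3 (0.51 log units; beyond the scatter) and is the only step read so far, so the group at this position of the shared core can shift the number beyond the scatter. The group that leaves carries a ring nitrogen and a hydrogen-bond acceptor, while the group that enters carries a fluorine and no hydrogen-bond acceptor, and this single step cannot separate the loss of the one from the gain of the other. Nothing available here accounts for the step.

Still open, going by these compounds, is whether plain phenyl would already give this lower number or whether the fluorine is needed. On these data alone, it is also open whether a chlorine, a methoxy group or an amine in the fluorine's place would follow compound 3.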